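This account rests on a few compounds, and the source may have more. Where it says the series, first, only, none or still open, it means among the compounds named here.

Working notes on the series.

Three compounds carry numbers in a functional assay on HCT-116 cells (Homo sapiens) for antiproliferative activity, read by sulforhodamine B assay, with a stated time of 72 h; on this read-out lower numbers stand for stronger inhibition and higher numbers for weaker inhibition. Compound 1 `Cn1ncc(Cl)c1-c1cc(C(=O)N[C@@H]2CN[C@H](CCN3CCCCC3)C[C@H]2c2ccc(Cl)c(Cl)c2)oc1Cl` gives 1020 nM and stands lowest of the three; compound 2 `CNC(=O)C[C@@H]1C[C@@H](c2ccc(F)c(F)c2)[C@H](NC(=O)c2cc(-c3c(Cl)cnn3C)c(Cl)o2)CN1` gives 1100 nM, which lies within the scatter of compound 1, so no order between the two can be read. Compound 3 `O=C(N[C@@H]1CNCC[C@H]1c1ccc(Cl)cc1)c1ccc(-c2ncnc3c2CCC3O)s1`, built on a different core, gives 23000 nM, a gap to compound 1 that lies beyond the scatter. For the measured compounds named here, no pair of measured compounds differs in one place only, so no single step has been measured.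

Compound 4 `Cn1ncc(Cl)c1-c1cc(C(=O)N[C@@H]2CN[C@H](CC(=O)NC3CCC3)C[C@H]2c2ccc(Cl)c(Cl)c2)oc1Cl` is the next member to be tested in this assay. It is derived from compound 1 by one change: cyclobutylcarbamoyl in place of (piperidin-1-yl)methyl on a saturated chain carbon bound to a saturated ring carbon. Going by the values given here, the data hold no measured step of this kind, and the shared core with the dichlorophenyl substituent is kept. The expectation for compound 4 rests on compound 1 alone, with its value of 1020 nM as the anchor, and the step from compound 1 to compound 4 is estimated as a 1.2-fold higher number from compound 1 to compound 4 (0.07 log units; within the scatter), that is, no change beyond the usual scatter in either direction. Compound 4 is therefore expected to give about 1200 nM in this assay, with a range from 500 nM to 3000 nM.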

Compound 4, half-maximal inhibitory concentration: 430 nM
For compound 4 the middle estimate is 2.8-fold (0.45 log units) above the measured one; the whole stated range lies above it.
By their numbers in this assay, from the lowest: compound 4; then compounds 1 and 2 (each within the scatter of the next); then compound 3.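

For the compounds shown here, on a saturated chain carbon bound to a saturated ring carbon, the first measured step in this assay is a 2.4-fold lower number from compound 1 to compound 4 (0.38 log units; beyond the scatter) and shows that this place on the shared core responds to a change of group, though only modestly. The (piperidin-1-yl)methyl group is not needed to keep the number at this level, since cyclobutylcarbamoyl, which replaces a six-membered non-aromatic ring with a hetero atom by a four-membered ring of carbon only and adds a hydrogen-bond donor, gives the lower number. Several features change together in this one step, and nothing measured here gives a reason for it or assigns it to any one of them.

Going by these compounds, it remains open whether the carbamoyl link or the cyclobutyl ring carries the step, which a methyl amide, a cyclohexyl amide or a ketone in the same place would separate, and how a carboxylic acid or a primary amine on the chain would read. Also open, on these data alone, is whether the step holds with a 4-chlorophenyl group in place of the dichlorophenyl substituent on the shared core.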